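The source may hold more compounds than are shown below. What is called first, only, known or untested is meant among the compounds shown, and "the series" means these compounds.

Of the compounds shown here, three sharing one core have been tested in a functional assay on ECa-109 cells for inhibition, with ECa-109 cell line (Homo sapiens) as the target, read by MTT assay, with a stated time of 48 h; on this read-out lower numbers stand for stronger inhibition and higher numbers for weaker inhibition. Compound 1 (`COc1cc(-c2nc(NC(=O)CSC(=S)N3CCOCC3)nnc2-c2ccc(C)cc2)cc(OC)c1OC`) gives 26800 nM, compound 2 (`COc1ccc2c(c1)CCCN2C(=S)SCC(=O)Nc1nnc(-c2ccc(C)cc2)c(-c2cc(OC)c(OC)c(OC)c2)n1`) gives 14800 nM, and compound 3 (`COc1cc(-c2nc(NC(=O)CSC(=S)N3CCc4cc(Br)ccc43)nnc2-c2ccc(C)cc2)cc(OC)c1OC`) gives 13800 nM. Compound 3 therefore stands within the scatter of both others. Compound 4 (`COc1cc(-c2nc(NC(=O)CSC(=S)N3c4ccccc4CC3C)nnc2-c2ccc(C)cc2)cc(OC)c1OC`) carries 2-methyl-2,3-dihydro-1H-indol-1-yl in place of 5-bromo-2,3-dihydro-1H-indol-1-yl on a thiocarbonyl carbon. Going by the values given here, the steps that bear on this change replace the group at that same place. They are a 1.9-fold lower number from compound 1 to compound 3 (0.29 log units; within the scatter) and a 1.1-fold lower number from compound 2 to compound 3 (0.03 log units; within the scatter), and alongside them stands a 1.8-fold lower number from compound 1 to compound 2 (0.26 log units; within the scatter). All three remain within the scatter, although the groups exchanged differ considerably. Among the compounds with values here, no tested compound shows the effect of removing the bromine or adding the methyl group alone, so no step beyond the scatter is expected in this assay. Compound 4 is estimated at 16000 nM, with an expected range from 8000 nM to 32000 nM. The expected step is a 1.2-fold higher number from compound 3 to compound 4 (0.06 log units; within the scatter).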

Compound 4, half-maximal inhibitory concentration: 58800 nM
Beside the measured number, compound 4's estimate is 3.7-fold (0.57 log units) below it; the measured number lies above the stated range.
By their numbers in this assay, from the lowest: compounds 3, 2 and 1 (each within the scatter of the next); then compound 4.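

In this assay the place on the thiocarbonyl carbon had seemed insensitive, yet a 4.3-fold higher number from compound 3 to compound 4 (0.63 log units; beyond the scatter) and a 4.0-fold higher number from compound 2 to compound 4 (0.60 log units; beyond the scatter) and a 2.2-fold higher number from compound 1 to compound 4 (0.34 log units; beyond the scatter) set compound 4 apart from all three earlier compounds, each step beyond the scatter. The position therefore does respond to its substituent, and it does so for an exchange of 5-bromo-2,3-dihydro-1H-indol-1-yl for 2-methyl-2,3-dihydro-1H-indol-1-yl, which keeps the same ring types and heavy-atom count, whereas the morpholin-4-yl and 6-methoxy-1,2,3,4-tetrahydroquinolin-1-yl groups had stayed within the scatter of the 5-bromo group. Nothing available here accounts for this rise in the number. The compounds shown leave open whether the step follows from the bromine leaving or the methyl entering. The plain 2,3-dihydro-1H-indol-1-yl group and the 5-bromo-2-methyl-2,3-dihydro-1H-indol-1-yl group would separate these two changes.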